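Adding Bromine to a Weak Dopamine Beta-Hydroxylase Inhibitor

The source may report more compounds than this note shows. Statements on the series, on what has been measured and on what is new or still open speak of the compounds shown alone.

Compound 1 `COc1ccc(Cn2cc[nH]c2=S)cc1` is a small thione-bearing molecule. In an assay on isolated protein for inhibition of Dopamine beta-hydroxylase (Rattus norvegicus) (on this read-out higher numbers stand for weaker inhibition and lower numbers for stronger inhibition), compound 1 gives 204000 nM, the highest of the two numbers recorded here. Its nearest neighbour, compound 2 `Cc1cc(Cn2cc[nH]c2=S)ccc1O`, gives 49000 nM in this assay, a difference beyond the usual scatter. Compound 3 `COc1ccc(Cn2cc[nH]c2=S)cc1Br` has not been tested; it differs from compound 1 by bromo in place of hydrogen on an aromatic carbon. For the measured compounds named here, no measured pair here shows what such a change does, so the expected step from compound 1 to compound 3, a 1.7-fold lower number from compound 1 to compound 3 (0.23 log units; within the scatter), is small and uncertain. Compound 3 is expected to give about 120000 nM, between 40000 nM and 400000 nM.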

Compound 3, half-maximal inhibitory concentration: 83200 nM
For compound 3 the middle estimate is 1.4-fold (0.16 log units) above the measured one; the range from low to high includes it.
By their numbers in this assay, from the lowest: compounds 2 and 3 (each within the scatter of the next); then compound 1.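

In this assay, bromo in place of hydrogen on an aromatic carbon, ortho to a methoxy group, gives a 2.5-fold lower number from compound 1 to compound 3 (0.39 log units; beyond the scatter), a modest step but one beyond the usual scatter. This position therefore accepts a bromine, and inhibition becomes somewhat stronger rather than being lost. Nothing available here explains why the step occurs. Going by these compounds, it remains open whether chlorine, an amine or a carboxylic acid at this same position would strengthen inhibition further or weaken it. On these data alone, whether bromo gives a similar step elsewhere on this ring also remains open.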